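The source may hold more compounds than are shown below. What is called first, only, known or untested is meant among the compounds shown, and "the series" means these compounds.

Measured so far in this set:

Compound 1, `c1ccc(Oc2ccccc2-c2nc3ccncc3s2)cc1`: > 50000 nM
Compound 2, `c1ccc(Oc2ncccc2-c2nc3ccncc3s2)cc1`: > 50000 nM
Compound 3, `CC(=O)Nc1ccc(Oc2ccccc2-c2nc3ccncc3s2)cc1`: > 50000 nM

All three were tested in an ADME assay on Vero cells (Chlorocebus sabaeus) for cytotoxicity; on this read-out higher numbers stand for lower toxicity in this test and lower numbers for higher toxicity in this test. For compound 1 the value > 50000 nM is a limit of the assay, not a number. For compound 2 the value > 50000 nM is likewise a limit. For compound 3 the value > 50000 nM is a limit as well. Every value shown thus rests at the limit of > 50000 nM in this assay, at which 3 of the 3 values shown sit.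

Compound 3 is made from compound 1 by one change, (acetamido in place of hydrogen on an aromatic carbon). The measured step is a step that the two limits leave unreadable from compound 1 to compound 3, so nothing can be said about whether this change moved the read-out, because both ends sit at the limit of > 50000 nM in this assay, at which 3 of the 3 values shown sit.

Compound 2 has a different core from compound 1; the difference between the two cores is not broken down here.

Compound 4, `CC(=O)Nc1ccc(Oc2ncccc2-c2nc3ccncc3s2)cc1`, has not yet been measured. It is made from compound 2 by the same change, (acetamido in place of hydrogen on an aromatic carbon). Going by the values given here, since the only earlier example of this change is a step that the two limits leave unreadable from compound 1 to compound 3, and since every compound in the set sits at the limit of > 50000 nM in this assay, at which 3 of the 3 values shown sit, the expected step from compound 2 to compound 4 is about a step that the limit leaves unreadable from compound 2 to compound 4 in this assay. Compound 4 is therefore expected to come out at around 80000 nM, most likely again as a limit rather than a number. The expected range for compound 4 runs from 30000 nM to 300000 nM.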

Compound 4, half-maximal cytotoxic concentration: > 50000 nM
Compound 4: only a limit was reported; the forecaster's own chance of this, stated with the estimate: 85%; the middle value lies beyond the limit too.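

Going by these compounds alone, putting acetamido in place of hydrogen on an aromatic carbon gives no step that can be read between compound 2 and compound 4, since both ends are limits of this assay and not numbers: the limit of > 50000 nM in this assay, at which 4 of the 4 values shown sit. The compounds shown leave open whether acetamido, or the difference between the two cores, moves this read-out in either direction at all.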